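Bromo to trifluoroethoxy on the aryl ring

The compounds below may be only part of what the source reports. "The series", "measured", "known", "first", "only" and "open" are said of these compounds alone.

Measured compounds:
compound 1 `COc1ccc([C@@H](CC(=O)O)NC(=O)[C@@H]2CCN2S(=O)(=O)c2cc(Cl)cc(Cl)c2)cc1`: 0.39 nM; 0.49 nM (2 entries)
compound 2 `O=C(O)C[C@@H](NC(=O)[C@@H]1CCN1S(=O)(=O)c1cc(Cl)cc(Cl)c1)c1ccc(Br)cc1`: 2.1 nM

In an assay on RPMI-8866 cells for inhibition of integrin alpha-4/beta-1 (Homo sapiens) (a higher number here means a weaker inhibitor, a lower number a stronger inhibitor), compound 1 gives 0.39 nM; 0.49 nM (2 entries), and the repeat entries agree (the several entries of compound 1 in this assay, 0.39 nM; 0.49 nM (2 entries)). In this assay, within the data shown here, compound 2 gives 2.1 nM, the only number it has here, and the weaker of the two values shown. Compound 3 `O=C(O)C[C@@H](NC(=O)[C@@H]1CCN1S(=O)(=O)c1cc(Cl)cc(Cl)c1)c1ccc(OCC(F)(F)F)cc1` is not yet measured. It differs from compound 2 in one place: 2,2,2-trifluoroethoxy in place of bromo on an aromatic carbon. Among the measured compounds shown here, no measured pair follows this exact change, so the step is estimated, expected to be a modest gain, a 2.1-fold lower number from compound 2 to compound 3 (0.32 log units; beyond the scatter), moving toward compound 1. Compound 3 is therefore expected to give about 1 nM, with a likely range from 0.3 nM to 4 nM.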

Compound 3, half-maximal inhibitory concentration: 1.4 nM
The estimate for compound 3 lay 1.4-fold (0.15 log units) below the measured number; the range from low to high includes it.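

In this assay, putting 2,2,2-trifluoroethoxy in place of bromo on this aromatic carbon, para to a large group, gives a 1.5-fold lower number from compound 2 to compound 3 (0.18 log units; within the scatter). So this position accepts a group of 6 heavy atoms in place of a single bromine with no change that can be told from ordinary assay scatter. Repeat measurements can agree closely in this assay: the several entries of compound 1 in this assay, 0.39 nM; 0.49 nM (2 entries)

On these data alone, whether an amine or a hydroxyl group would be accepted here as well remains open. So does the effect of a longer fluorinated chain.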